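Aryl Swap on the Triazole Nitrogen: Compound 4

This account rests on a few compounds, and the source may have more. Where it says the series, first, only, none or still open, it means among the compounds named here.

Compound 1 `N#CC1=C(N)Oc2c(N)cc3nc4ccccc4nc3c2C12C(=O)N(Cc1cnnn1-c1cccc(C(F)(F)F)c1)c1ccccc12` gives 18900 nM in a functional assay on HCT-116 cells (Homo sapiens) for antiproliferative activity, read by MTT assay, with a stated time of 48 h; on this read-out higher numbers stand for weaker inhibition and lower numbers for stronger inhibition. For compound 2 `CC(=O)Nc1ccc(-n2nncc2CN2C(=O)C3(C(C#N)=C(N)Oc4c(N)cc5nc6ccccc6nc5c43)c3ccccc32)cc1` this assay reports only a limit, > 50000 nM. For compound 3 `COc1ccc(-n2nncc2CN2C(=O)C3(C(C#N)=C(N)Oc4c(N)cc5nc6ccccc6nc5c43)c3ccccc32)cc1` this assay likewise reports only a limit, > 50000 nM. Compound 3 thus stands at the limit of > 50000 nM in this assay, at which 2 of the 3 values shown sit, and a step that the two limits leave unreadable from compound 2 to compound 3 cannot be read. Compound 4 `CCOc1ccccc1-n1nncc1CN1C(=O)C2(C(C#N)=C(N)Oc3c(N)cc4nc5ccccc5nc4c32)c2ccccc21` carries 2-ethoxyphenyl in place of 4-methoxyphenyl on an aromatic nitrogen. Among the compounds with values here, the steps that bear on this change are an at least 2.6-fold higher number from compound 1 to compound 2 (0.42 log units; beyond the scatter) and an at least 2.6-fold higher number from compound 1 to compound 3 (0.42 log units; beyond the scatter), both aryl swaps on the same nitrogen that run to the limit. Within the data shown here, no measured step separates one aryl from another away from that limit. Compound 4 is therefore expected to sit at or near the limit, the step that the limit leaves unreadable from compound 3 to compound 4 being expected to stay within the scatter. The estimate for compound 4 is 60000 nM, ranging from 20000 nM to 200000 nM.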

Compound 4, half-maximal inhibitory concentration: > 50000 nM
Compound 4 was reported as a limit; the forecaster's own chance of this, stated with the estimate: 75%; the middle value does not contradict the limit.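

Working from this assay, the weakening is not confined to the two aryl groups with a substituent at the 4-position, since 2-ethoxyphenyl also gives an at least 2.6-fold higher number from compound 1 to compound 4 (0.42 log units; beyond the scatter). The steps among compound 2, compound 3 and compound 4 cannot be read. Of the aryl groups shown, only the 3-(trifluoromethyl)phenyl of compound 1 stays off the limit: the limit of > 50000 nM in this assay, at which 3 of the 4 values shown sit.

As far as these compounds go, whether 4-acetamidophenyl, 4-methoxyphenyl and 2-ethoxyphenyl differ from one another stays open. So does what an amine or a carboxylic acid on this aryl ring would give in this assay.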